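The compounds below may be only part of what the source reports. "The series", "measured", "known", "first", "only" and "open" are said of these compounds alone.

Three amides on a shared core have been measured so far in a functional assay on HCT-116 cells (Homo sapiens) for inhibition, read by MTT assay, with a stated time of 48 h; on this read-out higher numbers stand for weaker inhibition and lower numbers for stronger inhibition. Compound 1 (`CCCCC(=O)N(Cc1ccc(OC)c(O)c1)c1cc(OC)c(OC)c(OC)c1`) gives 170 nM there, compound 2 (`C/C=C/C=C/C(=O)N(Cc1ccc(OC)c(O)c1)c1cc(OC)c(OC)c(OC)c1`) gives 180 nM there, and compound 3 (`CCC/C=C/C(=O)N(Cc1ccc(OC)c(O)c1)c1cc(OC)c(OC)c(OC)c1`) gives 95 nM on the same read-out. Compound 3 cannot be told apart from the other two, with a 1.8-fold lower number from compound 1 to compound 3 (0.25 log units; within the scatter) and a 1.9-fold lower number from compound 2 to compound 3 (0.28 log units; within the scatter) as its steps. The third pair is no different, with a 1.1-fold higher number from compound 1 to compound 2 (0.02 log units; within the scatter) as the whole gap.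

Compound 4 (`COc1ccc(CN(C(=O)CO)c2cc(OC)c(OC)c(OC)c2)cc1O`) has hydroxymethyl in place of pent-1-en-1-yl on a carbonyl carbon. The measured steps bear on this only indirectly. They exchange butyl, pent-1-en-1-yl and penta-1,3-dien-1-yl at that carbonyl carbon, and none of them brings in hydroxymethyl. Their small size therefore sets no firm limit on this larger exchange. A step toward a higher number in this assay is expected, probably modest but beyond the scatter, starting from compound 3 at 95 nM in this comparison. The expected change is a 3.2-fold higher number from compound 3 to compound 4 (0.50 log units; beyond the scatter) on this reasoning. For compound 4 the estimated value is 300 nM with an expected range of 60 nM to 1500 nM in this measurement.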

Compound 4, half-maximal inhibitory concentration: 520 nM
Compound 4: the middle estimate sits 1.7-fold (0.24 log units) below what was measured; low and high end bracket the measured number.
By their numbers in this assay, from the lowest: compounds 3, 1 and 2 (each within the scatter of the next); then compound 4.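

Among butyl, pent-1-en-1-yl and penta-1,3-dien-1-yl on the carbonyl carbon, every step in this assay stayed within the scatter, so the earlier compounds showed no measurable response to changes at this position. Hydroxymethyl is the first group there to give a step beyond the scatter, and it does so against all three earlier compounds: a 5.5-fold higher number from compound 3 to compound 4 (0.74 log units; beyond the scatter), a 2.9-fold higher number from compound 2 to compound 4 (0.46 log units; beyond the scatter) and a 3.1-fold higher number from compound 1 to compound 4 (0.49 log units; beyond the scatter). The last of these can also be read as hydroxy in place of propyl on a saturated chain carbon bound to a carbonyl carbon, and no supporting measurement is available to explain the direction of any of these steps.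

The compounds shown leave open whether the higher number goes with the drop from 5 heavy atoms to 2 or with the entering hydroxy group; a plain methyl or ethyl on the carbonyl carbon would help to separate the two. Also open, as far as these compounds go, is how a methoxymethyl, an aminomethyl, a carboxylic acid or a chain longer than pent-1-en-1-yl at that place would read in this assay.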